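This account rests on a few compounds, and the source may have more. Where it says the series, first, only, none or still open, it means among the compounds named here.

The measured compounds in an assay on isolated protein for inhibition of phosphodiesterase 7 (Homo sapiens), read by scintillation proximity assay and cAMP accumulation, with a stated time of 1 h; a higher number here means a weaker inhibitor, a lower number a stronger inhibitor:
compound 1, `COC(=O)c1cccc(-c2ccc(CSc3nc(C(C)C)nc4ccccc34)cc2)c1`, gives only a limit, > 100000 nM.
compound 2, `CC(C)c1nc(SCc2ccc(-c3cccc(C(=O)O)c3)cc2)c2ccccc2n1`, gives 850 nM.

Compound 1 sits at the limit of > 100000 nM in this assay, at which 1 of the 2 values shown sits. Compound 2 holds the only number shown; the one further value shown is a limit. Within the data shown here, the single measured step is an at least 110-fold lower number from compound 1 to compound 2 (2.07 log units; beyond the scatter). Compound 3, `CC(C)c1nc(SCc2ccc(-c3ccc(C(=O)O)cc3)cc2)c2ccccc2n1`, differs from compound 2 by 4-carboxyphenyl in place of 3-carboxyphenyl on an aromatic carbon. Among the measured compounds shown here, no measured step moves a carboxyphenyl between ring positions, so an at least 110-fold lower number from compound 1 to compound 2 (2.07 log units; beyond the scatter) does not bear directly on this change. The step from compound 2 to compound 3 in this assay is expected to be a 1.8-fold higher number from compound 2 to compound 3 (0.25 log units; within the scatter), near the scatter. Compound 3 is therefore estimated at 1500 nM, within 300 nM to 8000 nM.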

Compound 3, half-maximal inhibitory concentration: 930 nM
Beside the measured number, compound 3's estimate is 1.6-fold (0.21 log units) above it; the measured number falls inside the stated range.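

In this assay, 4-carboxyphenyl in place of 3-carboxyphenyl gives a 1.1-fold higher number from compound 2 to compound 3 (0.04 log units; within the scatter), so these two placements of the carboxyl group cannot be told apart here. Against the 3-(methoxycarbonyl)phenyl of compound 1, 4-carboxyphenyl also gives a large change, an at least 100-fold lower number from compound 1 to compound 3 (2.03 log units; beyond the scatter). That step starts from a limit, not a number: the limit of > 100000 nM in this assay, at which 1 of the 3 values shown sits.

The compounds shown leave open whether a primary amide or a tetrazole could stand in for the carboxyl group on this ring. They also leave open how a 4-(methoxycarbonyl)phenyl would read.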